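Compound 3: hydrogen replacing the 4-fluorophenyl group

This account rests on a few compounds, and the source may have more. Where it says the series, first, only, none or still open, it means among the compounds named here.

In a functional assay on MGC-803 cells (Homo sapiens) for antiproliferative activity, read by CellTiter-Glo, with a stated time of 72 h (on this read-out higher numbers stand for weaker inhibition and lower numbers for stronger inhibition), compound 1 `O=C(NO)c1ccc(/C=C/c2ccnc(-c3cc(F)ccc3O)c2)cc1` gives 1920 nM. Compound 2 `O=C(NO)c1ccc(/C=C/c2ccnc(-c3ccc(F)cc3)c2)cc1` reads > 10000 nM in this assay, and this is a limit of the assay, not a number. Its position is therefore known only as a bound.

Compound 3 `O=C(NO)c1ccc(/C=C/c2ccncc2)cc1` follows from compound 2 by hydrogen in place of 4-fluorophenyl on an aromatic carbon.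

Among the measured compounds shown here, the one measured step bearing on this change is an at least 5.2-fold higher number from compound 1 to compound 2 (0.71 log units; beyond the scatter), which lies beyond the scatter. That step is a swap of 5-fluoro-2-hydroxyphenyl for 4-fluorophenyl, not a removal, so it is only a rough guide. For the measured compounds named here, it shows that inhibition can be lost through a change to this group, but no measured compound shows the effect of removing it. No large gain is expected, and compound 3 is expected to remain weak, with a reading at the limit about as likely as a number.

The expected change is an at least 1.2-fold lower number from compound 2 to compound 3 (0.09 log units; that floor lies within the scatter), an estimate that starts from a limit. For compound 3 the estimated value is 8000 nM, with an expected range of 2500 nM to 25000 nM.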

Compound 3, half-maximal inhibitory concentration: 3930 nM
Compound 3: middle estimate off by 2.0-fold (0.31 log units), on the high side; the range from low to high includes it.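

In this assay, removing the 4-fluorophenyl group costs no inhibition: hydrogen at this place, next to the ring nitrogen, gives an at least 2.5-fold lower number from compound 2 to compound 3 (0.40 log units; beyond the scatter). Hydrogen in place of 5-fluoro-2-hydroxyphenyl gives a 2.0-fold higher number from compound 1 to compound 3 (0.31 log units; beyond the scatter), which places hydrogen between the two aryl groups: one of them reads better than hydrogen and the other worse, and an aryl group at this place is therefore not favourable or unfavourable as such. The reading of compound 2 is a limit of the assay and not a number, and the step from it gives only a floor for the size of the change: the limit of > 10000 nM in this assay, at which 1 of the 3 values shown sits.

As far as these compounds go, compound 1 and compound 2 differ both in the hydroxyl group and in where the fluorine sits, and the share of each in the gap between them remains open, as does whether 2-hydroxyphenyl without fluorine or 2-methoxyphenyl would hold the reading of compound 1. Also open, from the compounds shown here alone, is how a small group at this place, such as an amine or a methyl group, would compare with hydrogen.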